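Benzylcarbamoyl in Place of Phenethyloxy on the Shared Core

This account rests on a few compounds, and the source may have more. Where it says the series, first, only, none or still open, it means among the compounds named here.

Of the compounds shown here, three on a shared core have been measured in a functional assay on HEK293 cells for agonist activity at G-protein coupled receptor 39 (Homo sapiens), read by scintillation proximity assay and inositol phosphate accumulation, with a stated time of 75 min, in the presence of a further agent that is not named here; on this read-out lower numbers stand for an effect already at smaller amounts and higher numbers for an effect only at larger amounts of compound. Compound 1 `Cc1nn(-c2ncnc3nc[nH]c23)c2c1C(OCc1cc(F)cc3c1OCOC3)CC(=O)N2` gives 1.5 nM. Compound 2 `Cc1nn(-c2ncnc3nc[nH]c23)c2c1C(OCCc1ccccc1)CC(=O)N2` gives 3 nM. Compound 3 `CCC(C(=O)NC1CC(=O)Nc2c1c(C)nn2-c1ncnc2nc[nH]c12)c1ccccc1` gives 5 nM. For the measured compounds named here, the one single-point step among them, a 2.0-fold higher number from compound 1 to compound 2 (0.30 log units; within the scatter), is within the scatter, and the values of compound 2 and compound 3 are likewise no further apart than repeated measurements would be, so compound 2 stands in the middle of a group that the data do not separate.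

The unmeasured compound 4 `Cc1nn(-c2ncnc3nc[nH]c23)c2c1C(C(=O)NCc1ccccc1)CC(=O)N2` differs from compound 2 in one place: benzylcarbamoyl in place of phenethyloxy on a saturated ring carbon. Going by the values given here, no measured step exchanges an ether for an amide at this saturated ring carbon. Compound 3 shows that an amide-linked phenyl-bearing group on the core gives 5 nM, and compound 2 shows that an ether-linked one gives 3 nM, which together suggest the change is tolerated. Compound 4 is therefore expected to stay close, with a 2.0-fold higher number from compound 2 to compound 4 (0.30 log units; within the scatter) estimated as the likely step, and its value in this assay is estimated at 6 nM, within a range from 1.5 nM to 25 nM.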

Compound 4, half-maximal effective concentration: 5 nM
Beside the measured number, compound 4's estimate is 1.2-fold (0.08 log units) above it, within the range that was stated.
By their numbers in this assay, from the lowest: compounds 1, 2, 3 and 4 (each within the scatter of the next, the first and the last beyond it).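

In this assay the exchange of phenethyloxy for benzylcarbamoyl on the saturated ring carbon, three ring bonds from the ring nitrogen, amounts to a 1.7-fold higher number from compound 2 to compound 4 (0.22 log units; within the scatter) and so does not separate the two compounds. For the compounds shown here, this is the first direct reading at this position of a change in the link itself, and it shows that the number stays within the scatter when an ether oxygen gives way to a carbonyl and the amide hydrogen, with the phenyl ring kept in both groups. The entering group carries a hydrogen-bond donor and the leaving group none, yet nothing in this single step ties that difference to the read-out, and no independent measurement is at hand to explain the result.

The compounds shown leave open whether the amide hydrogen matters at all, which an N-methyl amide at this carbon would test, and whether the phenyl ring is needed, which a plain acetamide or a primary amine there would address. They also leave open how far the link can be stretched or charged, as with a longer chain between the carbonyl and the phenyl ring or a carboxylic acid on the same carbon.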